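The source may report more compounds than this note shows. Statements on the series, on what has been measured and on what is new or still open speak of the compounds shown alone.

Compounds measured in a functional assay on SW-620 cells (Homo sapiens) for inhibition, read by MTT assay, with a stated time of 72 h; a higher number here means a weaker inhibitor of growth, a lower number a stronger inhibitor of growth:
- Compound 1 `Cc1cc(CN2CCN(c3c(Br)cnc4[nH]c(-c5nc(C)oc5C)nc34)CC2)no1`: 4570 nM
- Compound 2 `Cc1cc(CN2CCN(c3c(Cl)cnc4[nH]c(-c5cnn(C)c5)nc34)CC2)no1`: 1800 nM
- Compound 3 `Cc1nn(C)cc1-c1nc2c(N3CCN(Cc4ncn(C)n4)CC3)c(Cl)cnc2[nH]1`: 3140 nM

Compound 3 gives 3140 nM in this assay. That number lies within the usual scatter of both other measurements, those of compound 1 and compound 2, so it cannot be separated from either of them.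

The next compound to be tested is compound 4 `Cc1nn(C)cc1-c1nc2c(N3CCN(Cc4cnccn4)CC3)c(Cl)cnc2[nH]1`. It carries pyrazin-2-yl in place of 1-methyl-1H-1,2,4-triazol-3-yl on a saturated chain carbon bound to an amine nitrogen in a ring.

Among the compounds with values here, no two measured compounds differ in only one place, so the data offer no direct measure of what this exchange does. All three measured compounds nevertheless give numbers in the same low micromolar region, although they differ in more than one place. The expectation therefore starts from compound 3 at 3140 nM and foresees no step beyond the scatter in this assay, in either direction.

The expected change is small: a 1.1-fold lower number from compound 3 to compound 4 (0.05 log units; within the scatter). For compound 4 the estimated value is 2800 nM, with an expected range from 1300 nM to 6000 nM.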

Compound 4, concentration for 50% growth inhibition: 1090 nM
Estimate against measurement, compound 4: 2.6-fold (0.41 log units) above, outside the stated range (below it).
By their numbers in this assay, from the lowest: compounds 4, 2, 3 and 1 (each within the scatter of the next, the first and the last beyond it).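

In this assay, within the data shown here, the exchange of 1-methyl-1H-1,2,4-triazol-3-yl for pyrazin-2-yl on a saturated chain carbon bound to an amine nitrogen in a ring gives a 2.9-fold lower number from compound 3 to compound 4 (0.46 log units; beyond the scatter) and is the first comparison in this set in which only one place differs. Among these compounds, it shows that the group at this position can shift the number beyond the scatter while the rest of the compound stays the same, something the earlier compounds could not show, as they differ from one another in more than one place. Nothing at hand accounts for the size or the direction of this step.

From the compounds shown here alone, whether a phenyl or a pyridin-2-yl group on the same saturated chain carbon would give a number like that of compound 4 or that of compound 3 remains open. Going by these compounds, it is also open whether the same exchange would give a step of this size alongside the other groups that compound 1 and compound 2 carry on the shared core, since this single step is all that bears on the question.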